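The source may hold more compounds than are shown below. What is called first, only, known or untested is meant among the compounds shown, and "the series" means these compounds.

Working notes on the series. Compound 1 `Cc1ccc(-c2cn(C/C=C3\OC(=O)C(OCc4ccccc4)=C3OCc3ccccc3)nn2)cc1` and compound 2 `CCCCCc1ccc(-c2cn(C/C=C3\OC(=O)C(OCc4ccccc4)=C3OCc3ccccc3)nn2)cc1` share the core and differ only at a saturated chain carbon bound to an aromatic carbon. In a functional assay on HepG2 cells (Homo sapiens) for antiproliferative activity, read by MTT assay, with a stated time of 72 h (on this read-out higher numbers stand for weaker inhibition and lower numbers for stronger inhibition), compound 1 gives only the limit > 100000 nM, not a number. In this assay compound 2 likewise gives only the limit > 100000 nM. The step from compound 1 to compound 2, a step that the two limits leave unreadable from compound 1 to compound 2, cannot be sized since both values sit at the limit of > 100000 nM in this assay, at which 3 of the 3 values shown sit.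

Compound 3 `COc1ccccc1-c1cn(C[C@H](O)[C@H]2OC(=O)C(OCc3ccccc3)=C2OCc2ccccc2)nn1` stands on the same footing: in this assay compound 3 gives only the limit > 100000 nM, so its position is a ceiling rather than a number, and the two other values shown are ceilings as well.

Compound 4 `O=C1O[C@H]([C@@H](O)Cn2cc(-c3cc(F)cc(F)c3)nn2)C(OCc2ccccc2)=C1OCc1ccccc1` differs from compound 3 by 3,5-difluorophenyl in place of 2-methoxyphenyl on an aromatic carbon. No measured step touches this kind of exchange; the only measured step, from compound 1 to compound 2, is itself unreadable, so nothing in the shown data sets a direction or a size for the change at this ring position. The expected outcome is therefore no shift beyond the scatter, with compound 4 expected to remain at the ceiling of this assay, a step estimated as a step that the limit leaves unreadable from compound 3 to compound 4. For compound 4 the estimated value in this assay is 150000 nM, in the expected range 40000 nM to 600000 nM.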

Compound 4, half-maximal inhibitory concentration: 11600 nM
For compound 4 the middle estimate is 13-fold (1.11 log units) above the measured one; measured number outside the range, below it.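

In this assay, among the compounds shown here, the exchange of 2-methoxyphenyl for 3,5-difluorophenyl on an aromatic carbon of the five-membered aromatic ring with 3 nitrogen gives the only readable step so far: an at least 8.6-fold lower number from compound 3 to compound 4 (0.93 log units; beyond the scatter). This shows that the group at this position can bring the read-out down from the limit, which the unreadable step between the two chain-substituted compounds could not show, and the size printed is a minimum, since compound 3 has a limit and not a number. Compound 4 is also the only compound shown with a number rather than a limit: the limit of > 100000 nM in this assay, at which 3 of the 4 values shown sit.

The single exchange removes the methoxy group and adds both fluorines at once, so the compounds shown do not separate the two contributions, and an unsubstituted phenyl, a 3-fluorophenyl or a 3,5-dichlorophenyl at this position would be needed to do so. Also open, from the compounds shown here alone, is whether 3,5-difluorophenyl has a similar effect on the core of compound 1, and how an amine or a carboxylic acid on this aromatic ring would read out.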